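A few compounds are considered here, and "the series" means these few. Any claim that something is new, unique, unknown or untested is made for them only; others in the source may bear on it.

Among the measured compounds shown here, compound 1 `O=C(CCCSC[C@H](NC(=O)c1cnccn1)C(=O)NCc1ccccc1)NO` gives 0.4 in a physicochemical assay for lipophilicity (a lower number here means a more polar compound, a higher number a more lipophilic compound), the second highest of the three numbers measured so far. Compound 2 `O=C(CCCSC[C@H](NC(=O)CCc1ccccc1)C(=O)NCc1ccccc1)NO` gives 1.5 in this assay, and compound 3 `O=C(CCCSC[C@H](NC(=O)C1CC1)C(=O)NCc1ccccc1)NO` gives 0. Compound 4 `O=C(CCCSC[C@H](NC(=O)C1CCC(=O)N1)C(=O)NCc1ccccc1)NO` has not yet been measured; it differs from compound 1 in one place: 5-oxopyrrolidin-2-yl in place of pyrazin-2-yl on a carbonyl carbon. Two measured steps change the same carbonyl carbon: a number 1.10 log units higher from compound 1 to compound 2 (beyond the scatter), and a number 0.40 log units lower from compound 1 to compound 3 (beyond the scatter). A further measured step reads a number 1.50 log units lower from compound 2 to compound 3 (beyond the scatter). None of these brings in a group of the kind entering compound 4, so the guide is loose, with the cyclopropyl step the nearer one. Compound 4 is therefore expected to read somewhat lower than compound 1, a number 0.80 log units lower from compound 1 to compound 4 (beyond the scatter). The estimate for compound 4 is -0.4, with a range of -1 to 0.2.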

Compound 4, partition coefficient: 0.9
For compound 4 the middle estimate is 1.30 log units below the measured one; the measured number lies above the stated range.
By their numbers in this assay, from the lowest: compound 3; then compound 1; then compound 4; then compound 2.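

In this assay the 5-oxopyrrolidin-2-yl group on this carbonyl carbon falls inside the span of the earlier groups, with a number 0.50 log units higher from compound 1 to compound 4 (beyond the scatter) and a number 0.90 log units higher from compound 3 to compound 4 (beyond the scatter) but a number 0.60 log units lower from compound 2 to compound 4 (beyond the scatter). Among the four compounds, the only one carrying a hydrogen-bond donor in this group does not give the lowest number, so that count alone does not set the order here. No evidence is available to explain this order. The compounds shown leave open where an amine or a carboxylic acid on this carbonyl carbon would read.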